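Piperazine thiocarbamate series: aryl for cyclohexyl on the ring nitrogen

This account rests on a few compounds, and the source may have more. Where it says the series, first, only, none or still open, it means among the compounds named here.

Compound 1 `Nc1nc(N)c2cc(CSC(=S)N3CCN(C4CCCCC4)CC3)ccc2n1` is the point of departure. For the measured compounds named here, in a functional assay on HCT-116 cells (Homo sapiens) for antiproliferative activity, read by MTT assay, with a stated time of 72 h (a higher number here means a weaker inhibitor, a lower number a stronger inhibitor), compound 1 gives 8400 nM, the highest of the two numbers so far; its nearest neighbour is compound 2 `COc1ccc(N2CCN(C(=S)SCc3ccc4nc(N)nc(N)c4c3)CC2)cc1`, which in this assay gives 2270 nM. Going by the values given here, the one recorded step, a 3.7-fold lower number from compound 1 to compound 2 (0.57 log units; beyond the scatter), comes from placing 4-methoxyphenyl in place of cyclohexyl on an amine nitrogen in a ring. Compound 3 `Nc1nc(N)c2cc(CSC(=S)N3CCN(c4ccccc4[N+](=O)[O-])CC3)ccc2n1` carries the change (2-nitrophenyl in place of cyclohexyl on an amine nitrogen in a ring). Among the compounds with values here, this is the same kind of exchange, an aromatic ring in place of the cyclohexyl on the piperazine nitrogen, so the step to compound 2 is the only direct guide, and it points to a modest drop in the number. A step of similar size and direction is expected for compound 3, namely a 2.8-fold lower number from compound 1 to compound 3 (0.45 log units; beyond the scatter). Compound 3 is therefore estimated at 3000 nM, within a range of 1200 nM to 8000 nM.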

Compound 3, half-maximal inhibitory concentration: 5520 nM
For compound 3 the middle estimate is 1.8-fold (0.26 log units) below the measured one; the range from low to high includes it.
By their numbers in this assay, from the lowest: compound 2; then compounds 3 and 1 (each within the scatter of the next).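

In this assay an aromatic ring on the ring nitrogen does not by itself set a compound apart from the cyclohexyl one: the series shows a 1.5-fold lower number from compound 1 to compound 3 (0.18 log units; within the scatter) with 2-nitrophenyl in place of cyclohexyl, so the step seen with 4-methoxyphenyl is not shared by every aromatic group. The choice of aromatic group matters at this position, with a 2.4-fold higher number from compound 2 to compound 3 (0.39 log units; beyond the scatter) on exchanging 4-methoxyphenyl for 2-nitrophenyl. Nothing measured in the series accounts for this difference between the two aromatic groups.

The two aromatic groups differ both in their substituent and in where it sits on the ring, and the compounds shown do not separate these two changes. Unsubstituted phenyl, 4-nitrophenyl or 2-methoxyphenyl on the same nitrogen would tell them apart.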